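The compounds below may be only part of what the source reports. "The series", "measured", "known", "first", "only" and "open" are said of these compounds alone.

Two measured compounds frame the question. Compound 1 `COc1cc(-c2cc(/C=C/C(=O)c3ccc(Cl)c(Cl)c3)[nH]n2)cc(OC)c1OC` gives -25% in a functional assay on RPMI-8226 cells (Homo sapiens) for cytotoxicity, read by sulforhodamine B assay, with a stated time of 48 h, tested at 100 uM (on this read-out lower numbers stand for a stronger effect and higher numbers for a weaker effect at the one concentration tested), and compound 2 `COc1ccc(C(=O)/C=C/c2cc(-c3cc(OC)c(OC)c(OC)c3)n[nH]2)cc1OC` gives -41% in the same assay. For the measured compounds named here, of the two numbers, compound 2 stands at the lower and therefore stronger end, its only neighbour being compound 1; the single measured step, a number 16 percentage points lower from compound 1 to compound 2 (beyond the scatter), came from the exchange of the aryl group on the carbonyl carbon.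

Compound 3 `COc1ccc(C(=O)/C=C/c2cc(-c3cc(OC)c(OC)c(OC)c3)n[nH]2)cc1` has not yet been measured in this assay. It differs from compound 2 in one place: hydrogen in place of methoxy on an aromatic carbon. Going by the values given here, this change touches the same carbonyl-linked ring as the measured step, but it removes one methoxy rather than swapping the whole group, so the only step in hand bears on it indirectly. Since the full exchange from compound 1 to compound 2 moved the number by a modest amount, a smaller change at the same ring is expected to move it less, most likely within the scatter or somewhat toward weaker.

Compound 3 is therefore expected to give about -32% in this assay, in a range from -55% to -10%, a step of a number 9 percentage points higher from compound 2 to compound 3 (within the scatter).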

Compound 3, a percentage reported as activity, at one concentration (the size of the read-out at that concentration, not a potency): -34%
Compound 3: middle estimate off by 2 percentage points, on the high side, and the stated range covers the measured number.
By their numbers in this assay, from the lowest: compounds 2, 3 and 1 (each within the scatter of the next, the first and the last beyond it).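

In this assay, removing one methoxy to turn 3,4-dimethoxyphenyl into 4-methoxyphenyl gives a number 7 percentage points higher from compound 2 to compound 3 (within the scatter), so at this place, on an aromatic carbon ortho to a methoxy group, the read-out does not separate hydrogen from methoxy. The exchange of the aryl group on the carbonyl carbon now has a second reading: 4-methoxyphenyl in place of 3,4-dichlorophenyl gives a number 9 percentage points lower from compound 1 to compound 3 (within the scatter), whereas 3,4-dimethoxyphenyl in that role gave a number 16 percentage points lower from compound 1 to compound 2 (beyond the scatter), so of these two exchanges only the second stands clear of the scatter. Nothing at hand accounts for these numbers.

As far as these compounds go, whether the remaining methoxy of compound 3 contributes at all stays open, as does the question of whether a hydroxy group, an amine or a carboxylic acid on the same ring would give a number that stands apart from those of compound 2 and compound 3. From the compounds shown here alone, the aryl group at the other end of the core is the same in all three compounds, so its part in the read-out also remains unknown.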